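The source may report more compounds than this note shows. Statements on the series, on what has been measured and on what is new or still open speak of the compounds shown alone.

Of the compounds shown here, two have been tested in a functional assay on the whole organism (Tail, strain ICR) with Mus musculus as the target, in the tail flick test, with a stated time of 60 min, at a dose of 25 umol/kg by the oral route; a higher number here means a stronger effect of the compound at the dose given, a lower number a weaker effect. Compound 1, `O=C(CN(c1ncnc2c1ncn2C1CCCCO1)C1CC1)N[C@@H](CCC(=O)OCc1ccccc1)C(=O)OCc1ccccc1`, gives 34.7% in this assay. Compound 2, `N=C(N)NCCC[C@H](NC(=O)CN(c1nc(Cl)nc2[nH]cnc12)C1CC1)C(=O)OCc1ccccc1`, gives 30.6% in this assay, a number that lies within the usual scatter of the number for compound 1, so the two cannot be told apart on these measurements. Compound 3, `CC(C)C[C@H](NC(=O)CN(c1ncnc2c1ncn2C1CCCCO1)C1CC1)C(=O)OCc1ccccc1`, has not yet been measured in this assay. It differs from compound 1 in one place: isopropyl in place of (benzyloxycarbonyl)methyl on a saturated chain carbon, two bonds along the chain from an amide-type nitrogen and a carbonyl carbon. Among the compounds with values here, no pair of measured compounds shows what such a change does to the read-out, so the size of the step from compound 1 to compound 3 is uncertain; on the two numbers at hand, a step no larger than the scatter seems the most likely outcome. The step from compound 1 to compound 3 is therefore estimated at a number 4.7 percentage points lower from compound 1 to compound 3 (within the scatter). Compound 3 is expected to give about 30% in this assay, most likely between 15% and 45%.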

Compound 3, a percentage reported as activity, at one dose (the size of the read-out at that dose, not a potency): 34.2%
Estimate against measurement, compound 3: 4.2 percentage points below, within the range that was stated.
By their numbers in this assay, from the lowest: compounds 2, 3 and 1 (each within the scatter of the next).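

At this place, on a saturated chain carbon, two bonds along the chain from an amide-type nitrogen and a carbonyl carbon, this assay now has its first comparison of compounds that differ in one place: with isopropyl in place of (benzyloxycarbonyl)methyl, the step is a number 0.5 percentage points lower from compound 1 to compound 3 (within the scatter) and the two compounds cannot be told apart. The read-out at this one dose therefore stays within the scatter even though the six-membered aromatic ring of carbon only, the double bond outside aromatic rings and the hydrogen-bond acceptors of the side group are gone. Nothing shown here gives a reason for this result.

The compounds shown leave open whether a carboxylic acid or an amine on this chain would give a read-out beyond the scatter of compound 1. They also leave open what a longer chain without a ring would give.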